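The source may report more compounds than this note shows. Statements on the series, on what has been measured and on what is new or still open speak of the compounds shown alone.

Compound 1, `Cn1c(-c2ccc([N+](=O)[O-])cc2)nc2cc(C(F)(F)F)ccc21`: in an ADME assay on Vero cells (Chlorocebus sabaeus) for cytotoxicity (a lower number here means that less compound is tolerated, a higher number that more compound is tolerated), compound 1 gives > 100000 nM, which is a limit of the assay rather than a number.
Compound 2, `CN1CCN(CC(=O)Nc2ccc(-c3nc4cc(C(F)(F)F)ccc4n3C)cc2)CC1`: in this assay compound 2 gives > 100000 nM, again a limit.
Compound 3, `CCN(CC)CC(=O)Nc1ccc(-c2nc3cc(C(F)(F)F)ccc3n2C)cc1`: in this assay compound 3 gives 90000 nM.

Going by the values given here, compound 3 thus holds the only real number; the other two values are limits. The two measured steps, an at least 1.1-fold lower number from compound 1 to compound 3 (0.04 log units; that floor lies within the scatter) and an at least 1.1-fold lower number from compound 2 to compound 3 (0.04 log units; that floor lies within the scatter), each set only a floor that sits within the scatter, because their starting points rest at the limit of > 100000 nM in this assay, at which 2 of the 3 values shown sit.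

Compound 4, `CCC(=O)Nc1ccc(-c2nc3cc(C(F)(F)F)ccc3n2C)cc1`, differs from compound 3 by methyl in place of diethylamino on a saturated chain carbon bound to a carbonyl carbon. The step from compound 2 to compound 3 touched the same place and stayed within the scatter, so no shift beyond the scatter is expected here either. Compound 4 is therefore expected to show a 1.1-fold higher number from compound 3 to compound 4 (0.05 log units; within the scatter) in this assay. The estimated value of compound 4 is 100000 nM, with a range from 45000 nM to 220000 nM.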

Compound 4, half-maximal cytotoxic concentration: > 100000 nM
Compound 4 gave a limit, no number; the forecaster's own chance of this, stated with the estimate: 50%; the middle value lies on the limit itself.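

Methyl in place of diethylamino on a saturated chain carbon bound to a carbonyl carbon gives an at least 1.1-fold higher number from compound 3 to compound 4 (0.04 log units; that floor lies within the scatter) in this assay. Removing the diethylamino therefore produces no shift that can be told from the scatter, and compound 4 rests at a limit of the assay rather than at a number. The steps to compound 4 from compound 1 and compound 2 cannot be read because both ends of each are limits: the limit of > 100000 nM in this assay, at which 3 of the 4 values shown sit.

As far as these compounds go, whether a carboxylic acid or a longer chain at this place would bring the number down beyond the scatter stays open. So does how much compound 1, compound 2 and compound 4 differ from one another.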